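This account rests on a few compounds, and the source may have more. Where it says the series, first, only, none or still open, it means among the compounds named here.

Two measured compounds share a urea-linked quinoline ether core carrying a thiazolidinone bearing a difluorophenyl group. Compound 1 `COc1cc2c(Oc3ccc(NC(=O)NN4C(=O)CSC4c4c(F)cccc4F)cc3Cl)ccnc2cc1OCCCN1CCCC1` gives 480 nM in a functional assay on HT-29 cells (Homo sapiens) for antiproliferative activity, read by MTT assay, with a stated time of 72 h (on this read-out lower numbers stand for stronger inhibition and higher numbers for weaker inhibition), while compound 2 `COc1cc2c(Oc3c(F)cc(NC(=O)NN4C(=O)CSC4c4c(F)cccc4F)cc3F)ccnc2cc1OCCCN1CCc2sccc2C1` gives 1410 nM in this assay, the higher of the two numbers, and its gap to compound 1 lies beyond the scatter. Compound 3 `CCN1CCN(CCCCOc2cc3nccc(Oc4c(F)cc(NC(=O)NN5C(=O)CSC5c5c(F)cccc5F)cc4F)c3cc2OC)CC1` differs from compound 2 by a group of 9 heavy atoms (7 carbon, 2 nitrogen; one six-membered non-aromatic ring with 2 hetero atoms) in place of a group of 9 heavy atoms (7 carbon, 1 nitrogen, 1 sulfur; one five-membered aromatic ring with 1 hetero atom, one six-membered non-aromatic ring with 1 hetero atom), on a saturated chain carbon, three bonds along the chain from an oxygen on an aromatic ring. No comparable exchange has been measured, so any expectation rests on the two values alone. Compound 3 is expected near 900 nM, within 350 nM to 2500 nM. The estimated step from compound 2 to compound 3 is a 1.6-fold lower number from compound 2 to compound 3 (0.19 log units; within the scatter), a modest move that may not exceed the scatter.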

Compound 3, half-maximal inhibitory concentration: 830 nM
The estimate for compound 3 lay 1.1-fold (0.04 log units) above the measured number; the measured number falls inside the stated range.
By their numbers in this assay, from the lowest: compounds 1, 3 and 2 (each within the scatter of the next, the first and the last beyond it).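

At this place, on a saturated chain carbon, three bonds along the chain from an oxygen on an aromatic ring, (4-ethylpiperazin-1-yl)methyl replaces the group of compound 2 with a 1.7-fold lower number from compound 2 to compound 3 (0.23 log units; within the scatter) in this assay, so this assay does not separate the two groups. For the compounds shown here, this is the first change confined to one place, since compound 1 and compound 2 differ in more than one. No measurement here bears on why the two groups read alike. Still open, on these data alone, is whether a morpholine or a dimethylamino group at this place would read differently. Also open, as far as these compounds go, is whether the same exchange would read alike on the core of compound 1.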